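An Amino Group Where Larger Substituents Once Sat

The compounds below may be only part of what the source reports. "The series", "measured", "known", "first", "only" and "open" are said of these compounds alone.

Compound 3 `C[C@@H]1CCCN1c1c(C#N)c2c(N)ncnc2n1C` carries a hydrogen on the carbon between two ring nitrogen atoms of its core. In an assay on isolated protein for binding affinity to Leucine-rich repeat serine/threonine-protein kinase 2 variant G2019S (Homo sapiens), read by TR-FRET and LanthaScreen, with a stated time of 2 h (a lower number here means a stronger inhibitor, a higher number a weaker inhibitor), compound 3 gives 0.7 nM. Among the measured compounds shown here, that is the second highest of the three numbers measured so far: compound 1 `Cc1c(Nc2nc(N)c3c(C#N)c(N4CCC[C@H]4C)n(C)c3n2)cnn1C` gives 3 nM, and compound 2 `C[C@@H]1CCCN1c1c(C#N)c2c(N)nc(Nc3cn[nH]c3)nc2n1C` gives 0.4 nM. The change to compound 4 `C[C@@H]1CCCN1c1c(C#N)c2c(N)nc(N)nc2n1C` is amino in place of hydrogen on an aromatic carbon. For the measured compounds named here, two measured steps touch that same carbon. Compound 1 carries (1,5-dimethyl-1H-pyrazol-4-yl)amino there, and a 4.3-fold lower number from compound 1 to compound 3 (0.63 log units; beyond the scatter). Compound 2 carries (1H-pyrazol-4-yl)amino there, and a 1.8-fold higher number from compound 2 to compound 3 (0.24 log units; within the scatter). So the larger substituent at this carbon came with a higher number, while the smaller one stayed within the scatter of compound 3. The entering amino group is smaller again than either, and on that basis the step of no change at the digits printed from compound 3 to compound 4 (within the scatter) is expected to remain within the scatter, with no clear direction. Compound 4 is therefore expected to give about 0.7 nM, with a range from 0.3 nM to 2 nM.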

Compound 4, inhibition constant: 13 nM
Compound 4: middle estimate off by 19-fold (1.27 log units), on the low side; the measured number lies above the stated range.
By their numbers in this assay, from the lowest: compounds 2 and 3 (each within the scatter of the next); then compound 1; then compound 4.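

The amino group, the smallest substituent on this carbon among those shown, gives a 19-fold higher number from compound 3 to compound 4 (1.27 log units; beyond the scatter), so the numbers here do not simply rise with the size of the group. Removing the ring from that amino nitrogen also raises the number, with a 33-fold higher number from compound 2 to compound 4 (1.51 log units; beyond the scatter) on losing 1H-pyrazol-4-yl and a 4.3-fold higher number from compound 1 to compound 4 (0.64 log units; beyond the scatter) on losing 1,5-dimethyl-1H-pyrazol-4-yl. Since compound 3, with hydrogen, and compound 2, with a ring on the amino nitrogen, stay within the scatter of each other, the unsubstituted amino group of compound 4 stands apart from both.

Nothing measured here explains this rise. As far as these compounds go, it remains open whether a methylamino or a methoxy group on this carbon would give a number closer to that of compound 3 or that of compound 4.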